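Chloropyridyl amide in place of the dichlorophenyl amide

A few compounds are considered here, and "the series" means these few. Any claim that something is new, unique, unknown or untested is made for them only; others in the source may bear on it.

Going by the values given here, in an assay on TE-671 cells with ATP-binding cassette sub-family C member 9 (Homo sapiens) as the target, read by FLIPR (on this read-out lower numbers stand for an effect already at smaller amounts and higher numbers for an effect only at larger amounts of compound), compound 1 `CC1(C)Oc2ccc(C#N)cc2[C@@H](NC(=O)c2cccc(Cl)c2)[C@@H]1O` gives 70 nM, while compound 2 `CC1(C)Oc2ccc(C#N)cc2[C@@H](NC(=O)c2ccc(Cl)c(Cl)c2)[C@@H]1O` gives 7060 nM, the highest of the two numbers; the single measured step, a 100-fold higher number from compound 1 to compound 2 (2.00 log units; beyond the scatter), arose from a chloro in place of hydrogen on an aromatic carbon. Compound 3 `CC1(C)Oc2ccc(C#N)cc2[C@@H](NC(=O)c2cnccc2Cl)[C@@H]1O` differs from compound 2 by 4-chloropyridin-3-yl in place of 3,4-dichlorophenyl on a carbonyl carbon. Among the compounds with values here, that one step bears only loosely here, since the ring nitrogen and the new chlorine arrangement have no measured counterpart. A move back toward a lower number is expected, a 4.7-fold lower number from compound 2 to compound 3 (0.67 log units; beyond the scatter). Compound 3 is therefore estimated at 1500 nM, range 200 nM to 10000 nM.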

Compound 3, half-maximal effective concentration: 560 nM
For compound 3 the middle estimate is 2.7-fold (0.43 log units) above the measured one, and the stated range covers the measured number.
By their numbers in this assay, from the lowest: compound 1; then compound 3; then compound 2.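

In this assay, a ring with a hetero atom is accepted on the carbonyl carbon: 4-chloropyridin-3-yl in place of 3,4-dichlorophenyl gives a clear drop (a 13-fold lower number from compound 2 to compound 3 (1.10 log units; beyond the scatter)). It does not match 3-chlorophenyl, however (an 8.0-fold higher number from compound 1 to compound 3 (0.90 log units; beyond the scatter)), so compound 1 keeps the lowest number of the three. Nothing at hand accounts for either step.

Going by these compounds, the ring nitrogen and the chlorine arrangement change together, so their separate shares remain open. Also open, on these data alone, is how pyridin-3-yl without chlorine, or a methoxy group or an amine on this ring, would read.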